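A few compounds are considered here, and "the series" means these few. Any claim that something is new, unique, unknown or untested is made for them only; others in the source may bear on it.

Measured in an ADME assay on SJ-G2 cells (Homo sapiens) for cytotoxicity, read by MTT assay, with a stated time of 72 h; a lower number here means a stronger inhibitor of growth, a higher number a weaker inhibitor of growth:
- compound 1 `C=CCNC(=O)C1C(C(=O)O)[C@@H]2CC[C@H]1O2`: 10000 nM
- compound 2 `CCCCNC(=O)C1C(C(=O)O)[C@@H]2CC[C@H]1O2`: 10000 nM
- compound 3 `O=C(O)C1C(C(=O)Nc2ccccc2)[C@H]2CC[C@@H]1O2`: 10000 nM

Compound 2 gives 10000 nM, level with compound 1 and compound 3. The next candidate is compound 4 `O=C(O)C1C(C(=O)NCCCc2ccccc2)[C@H]2CC[C@@H]1O2`, and the change is phenyl in place of methyl on a saturated chain carbon, three bonds along the chain from an amide-type nitrogen.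

Among the compounds with values here, three measured steps bear on this: no change at the digits printed from compound 1 to compound 2 (within the scatter), no change at the digits printed from compound 2 to compound 3 (within the scatter) and no change at the digits printed from compound 1 to compound 3 (within the scatter). None moved the value, even with phenyl on the amide-type nitrogen. Within the data shown here, no measured compound has a phenyl at the end of a chain, so this evidence is indirect.

The expected outcome is no change at the digits printed from compound 2 to compound 4 (within the scatter), with no shift in either direction beyond the scatter. The estimate for compound 4 is 10000 nM, with an expected range of 4000 nM to 20000 nM.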

Compound 4, concentration for 50% growth inhibition: 10000 nM
For compound 4 middle estimate and measured number coincide at the digits printed; low and high end bracket the measured number.
By their numbers in this assay, from the lowest: compounds 1, 2, 3 and 4 (each within the scatter of the next).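

In this assay, phenyl in place of methyl on a saturated chain carbon, three bonds along the chain from an amide-type nitrogen, gives no change at the digits printed from compound 2 to compound 4 (within the scatter). An aromatic ring at this place, further out than the phenyl on the nitrogen of compound 3, therefore also leaves the number unmoved. Nothing available explains this result.

As far as these compounds go, whether an amine or a hydroxyl group at the end of this chain, or a longer chain, would shift the number remains open. So does the effect of changes to the shared core.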